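The source may report more compounds than this note shows. Statements on the series, on what has been measured and on what is new or still open speak of the compounds shown alone.

Measured so far in a functional assay on DU-145 cells (Homo sapiens) for inhibition, read by trypan blue exclusion, with a stated time of 96 h; a lower number here means a stronger inhibitor of growth, a higher number a weaker inhibitor of growth:
- compound 1 `COc1ccc(/C=C(/SCc2ccc(Cl)cc2)C(=O)c2ccc(Br)cc2)cc1O` gives 1000 nM
- compound 2 `O=C(/C(=C\c1cccc(Cl)c1Cl)SCc1ccc(Cl)cc1)c1ccc(Br)cc1` gives 10000 nM
- compound 3 `CN(C)c1ccc(/C=C(/SCc2ccc(F)cc2)C(=O)c2ccc(Br)cc2)cc1` gives 50000 nM

Compound 3 has the highest of these numbers, so it is the weakest growth inhibitor of the three, and its gaps to the other two lie beyond the scatter.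

The next compound, compound 4 `CN(C)c1ccc(/C=C(/SCc2ccc(Cl)cc2)C(=O)c2ccc(Br)cc2)cc1`, differs from compound 3 in one place: chloro in place of fluoro on an aromatic carbon. In words, this is chloro in place of fluoro on an aromatic carbon, turning the 4-fluorobenzyl group into 4-chlorobenzyl.

Among the compounds with values here, no measured step makes this swap. Within the data shown here, the only step available is a 10-fold higher number from compound 1 to compound 2 (1.00 log units; beyond the scatter), and it is a change elsewhere in the molecule, with chloro present on both sides. It shows that the series can move by a clear margin, but it says nothing direct about fluoro and chloro. Compounds 1 and 2 both carry the 4-chlorobenzyl group and both sit lower than compound 3, but they also differ from compound 3 in another group, so this is weak evidence.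

The estimated change is therefore small, a 2.0-fold lower number from compound 3 to compound 4 (0.30 log units; within the scatter), with a slight lean towards a lower number. The expected value for compound 4 is 25000 nM, with an estimated range from 7000 nM to 70000 nM.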

Compound 4, concentration for 50% growth inhibition: 10000 nM
Compound 4: middle estimate off by 2.5-fold (0.40 log units), on the high side; low and high end bracket the measured number.
By their numbers in this assay, from the lowest: compound 1; then compounds 2 and 4 (each within the scatter of the next); then compound 3.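

In this assay, within the data shown here, the step to the 4-chlorobenzyl group is a 5.0-fold lower number from compound 3 to compound 4 (0.70 log units; beyond the scatter), which shows for the first time that a single atom at this place on the ring can shift the number by more than the usual scatter, at least with 4-(dimethylamino)phenyl elsewhere in the molecule. With the 4-chlorobenzyl group now held fixed, replacing 2,3-dichlorophenyl with 4-(dimethylamino)phenyl gives no change at the digits printed from compound 2 to compound 4 (within the scatter), whereas replacing 3-hydroxy-4-methoxyphenyl with the same group gives a 10-fold higher number from compound 1 to compound 4 (1.00 log units; beyond the scatter), so among these three compounds only the 3-hydroxy-4-methoxyphenyl group sets its compound apart. Nothing shown here gives a reason for the size of any of these steps.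

The compounds shown leave open whether fluoro to chloro would bring a similar step with 3-hydroxy-4-methoxyphenyl or 2,3-dichlorophenyl in the place of 4-(dimethylamino)phenyl, as this swap is seen in only one pair. They also leave open how bromo, methyl or methoxy on that same aromatic carbon would compare with chloro.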